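The source may report more compounds than this note shows. Statements on the series, on what has been measured and on what is new or still open speak of the compounds shown alone.

Among the measured compounds shown here, in a functional assay on SK-MEL-28 cells (Homo sapiens) for cytotoxicity, read by CCK-8 assay, with a stated time of 24 h (a higher number here means a weaker inhibitor, a lower number a stronger inhibitor), compound 2 `COc1ccccc1Oc1c(N)nc(Cc2ccccc2)nc1OCCO` gives 14000 nM, the only true number so far. For the measured compounds named here, the only other compound measured, compound 1 `COc1ccccc1Oc1c(N)nc(-c2ccccc2)nc1OCCO`, gives > 80000 nM, which is a limit of the assay and not a number. The next compound, compound 3 `COc1ccccc1Oc1c(N)nc(-c2cccc(C)c2)nc1OCCO`, has 3-methylphenyl in place of the benzyl of compound 2, on an aromatic carbon between two ring nitrogen atoms: 3-methylphenyl in place of benzyl on an aromatic carbon. Going by the values given here, one measured step bears on this change: an at least 5.7-fold lower number from compound 1 to compound 2 (0.75 log units; beyond the scatter), where benzyl took the place of phenyl. Compound 3 goes back to a phenyl-type group, now carrying a methyl, so that step should largely reverse, giving a higher number. The effect of the methyl itself has not been measured. The expected change is a 3.6-fold higher number from compound 2 to compound 3 (0.55 log units; beyond the scatter). For compound 3 the estimated value is 50000 nM, with an expected range of 22000 nM to 110000 nM.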

Compound 3, half-maximal inhibitory concentration: 14700 nM
The estimate for compound 3 lay 3.4-fold (0.53 log units) above the measured number, outside the stated range (below it).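

At the aromatic carbon between two ring nitrogen atoms, a phenyl-type group directly on the ring no longer goes with a poor result: in this assay there is a 1.1-fold higher number from compound 2 to compound 3 (0.02 log units; within the scatter), so benzyl and 3-methylphenyl cannot be told apart here. A single methyl on the phenyl of compound 1 is enough for an at least 5.4-fold lower number from compound 1 to compound 3 (0.73 log units; beyond the scatter), so the direct link to the ring alone does not set compound 1 apart. Compound 1 stands at a limit of the assay and not at a number: the limit of > 80000 nM in this assay, at which 1 of the 3 values shown sits.

On these data alone, whether a methoxy group, a chlorine atom or a longer chain in place of this methyl would give a lower number remains open. So does what an amine on that phenyl ring would do.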